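The source may report more compounds than this note shows. Statements on the series, on what has been measured and on what is new or still open speak of the compounds shown alone.

Compound 1 `Nc1nc(NCc2ccccc2)c2ncn(/C=C3/CC3(CO)CO)c2n1`: > 24000 nM
Compound 2 `CCCNc1nc(N)nc2c1ncn2/C=C1/CC1(CO)CO`: > 24000 nM
Compound 3 `CSc1nc(N)nc2c1ncn2/C=C1/CC1(CO)CO`: > 20000 nM

All three entries are limits, not numbers. In an ADME assay on Akata cells (Homo sapiens) for cytotoxicity, with a stated time of 7 days (a higher number here means that more compound is tolerated, a lower number that less compound is tolerated), compound 3 stands at > 20000 nM, which is a limit.

Compound 4 `CCCCCCSc1nc(N)nc2c1ncn2/C=C1/CC1(CO)CO` turns the methylsulfanyl of compound 3 into hexylsulfanyl: pentyl in place of hydrogen on a saturated chain carbon bound to a sulfur. The measured steps that bear on this are a step that the two limits leave unreadable from compound 2 to compound 3 and a step that the two limits leave unreadable from compound 1 to compound 3, and a step that the two limits leave unreadable from compound 1 to compound 2 adds no more. Among the compounds with values here, none of them gives a size, so this assay offers no measured precedent for the change.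

The expected step is a number no higher from compound 3 to compound 4 (the limit leaves the size open), so none beyond the scatter is expected, though a lower tolerated concentration remains possible. For compound 4 the estimated value is 20000 nM, with an expected range of 7000 nM to 40000 nM.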

Compound 4, half-maximal cytotoxic concentration: > 20000 nM
Compound 4: no number, only a limit (the forecaster's own chance of this, stated with the estimate: 60%); the middle value lies on the limit itself.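

Within the data shown here, compound 4 joins compound 1, compound 2 and compound 3 in giving only a limit in this assay, so no step among them can be read. The compounds shown leave open whether hexylsulfanyl in place of methylsulfanyl changes the half-maximal cytotoxic concentration at all.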